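The compounds below may be only part of what the source reports. "The series", "measured", "known", "first", "only" and "open" are said of these compounds alone.

The measured compounds in an assay on LNCaP cells for inhibition of RAC-alpha serine/threonine-protein kinase (Homo sapiens); on this read-out higher numbers stand for weaker inhibition and lower numbers for stronger inhibition:
compound 1 `CCOCCN(C[C@@H](O)CN1CCCC2(CCN(c3ncnc4[nH]cc(C)c34)CC2)C1)S(=O)(=O)c1c(C)cccc1C` gives 1200 nM
compound 2 `Cc1cccc(C)c1S(=O)(=O)N1CCC[C@H]1[C@@H](O)CN1CCC[C@@]2(CCN(c3ncnc(N)c3C3CC3)C2)C1` gives 690 nM
compound 3 `Cc1cccc(C)c1S(=O)(=O)N1CCC[C@H]1[C@H](O)CN1CCC[C@@]2(CCN(c3ncnc(N)c3C3CC3)C2)C1` gives 13000 nM

Compound 3 stands at the highest number of the three in this assay; compound 1 lies well below it, and compound 2 lower still. Among the measured compounds shown here, the one step measured within this set, a 19-fold higher number from compound 2 to compound 3 (1.28 log units; beyond the scatter), is large, and because the fact that compounds 2 and 3 differ only in the configuration as drawn the whole of it falls to the configuration of the chain carbon.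

Compound 4 `Cc1cccc(C)c1S(=O)(=O)N1CCC[C@@H]1[C@@H](O)CN1CCC[C@@]2(CCN(c3ncnc(N)c3C3CC3)C2)C1` is not yet measured. It differs from compound 3 in this way: the two compounds have the same atoms and bonds and differ only in configuration as drawn: 2 of 3 stereo elements differ; a stereocentre at a saturated ring carbon is drawn S in compound 3 and R in compound 4; a stereocentre at a saturated chain carbon is drawn R in compound 3 and S in compound 4. For the measured compounds named here, the chain carbon thus returns to the configuration it has in compound 2, while the ring carbon takes a configuration that no measured compound carries. The step from compound 2 to compound 3 bears on the chain carbon only; nothing measured speaks to the ring carbon. A move back toward lower numbers is therefore expected in this assay, but with wide uncertainty, and the step of a 5.2-fold lower number from compound 3 to compound 4 (0.72 log units; beyond the scatter) is the estimated size. Compound 4 is expected to give 2500 nM, in the range 400 nM to 15000 nM.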

Compound 4, half-maximal inhibitory concentration: 2400 nM
Beside the measured number, compound 4's estimate is 1.0-fold (0.02 log units) above it; the range from low to high includes it.
By their numbers in this assay, from the lowest: compounds 2, 1 and 4 (each within the scatter of the next, the first and the last beyond it); then compound 3.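

In this assay, among the compounds shown here, a 3.5-fold higher number from compound 2 to compound 4 (0.54 log units; beyond the scatter) belongs wholly to the ring carbon and is the first measure of that centre, because of this: the fact that compounds 2 and 4 differ only in the configuration as drawn. This modest step stands against the large 19-fold higher number from compound 2 to compound 3 (1.28 log units; beyond the scatter) at the chain carbon, so both centres bear on the number, and among the compounds shown the lowest number comes with the ring carbon drawn S and the chain carbon drawn S. By contrast, a 5.4-fold lower number from compound 3 to compound 4 (0.73 log units; beyond the scatter) is a net step over both centres and cannot be assigned to either one alone.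

On these data alone, the pairing of ring carbon R with chain carbon R remains open, and with it whether the chain carbon step keeps its size when the ring carbon is drawn R. Also open is whether an amine in place of the hydroxyl on the chain carbon would show the same dependence on configuration.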